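Shrinking a ring substituent to trifluoromethyl

This account rests on a few compounds, and the source may have more. Where it says the series, first, only, none or still open, it means among the compounds named here.

In a toxicity assay on HepG2 2.2.15 cells (Homo sapiens) for cytotoxicity, read by CellTiter-Glo (on this read-out lower numbers stand for higher toxicity in this test and higher numbers for lower toxicity in this test), compound 1 `N#CC1CC(=O)N(c2cnn3c2CN(C(=O)Nc2cc(F)c(F)c(F)c2)C(C2CC2)C3)C1` gives > 200000 nM, which is a limit of the assay and not a true number. For the measured compounds named here, putting 2-(trifluoromethyl)-1,3-thiazol-5-yl in place of cyano gives compound 2 `O=C1CC(c2cnc(C(F)(F)F)s2)CN1c1cnn2c1CN(C(=O)Nc1cc(F)c(F)c(F)c1)C(C1CC1)C2`, and compound 2 reads 38500 nM, the only exact value so far. Compound 3 `O=C1CC(C(F)(F)F)CN1c1cnn2c1CN(C(=O)Nc1cc(F)c(F)c(F)c1)C(C1CC1)C2` carries trifluoromethyl in place of 2-(trifluoromethyl)-1,3-thiazol-5-yl on a saturated ring carbon. Going by the values given here, one measured step bears on this change: an at least 5.1-fold lower number from compound 1 to compound 2 (0.71 log units; beyond the scatter). That step brought in the very group that compound 3 gives up, so part of it may well be undone, though a single step is thin support. A higher number is therefore expected in this assay, meaning lower toxicity in this test. The expected change is a 2.9-fold higher number from compound 2 to compound 3 (0.46 log units; beyond the scatter). Compound 3 is estimated at 110000 nM, with an expected range from 40000 nM to 280000 nM.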

Compound 3, half-maximal cytotoxic concentration: 115000 nM
Beside the measured number, compound 3's estimate is 1.0-fold (0.02 log units) below it; low and high end bracket the measured number.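

In this assay, replacing the larger 2-(trifluoromethyl)-1,3-thiazol-5-yl with trifluoromethyl on this saturated ring carbon gives a 3.0-fold higher number from compound 2 to compound 3 (0.48 log units; beyond the scatter), so the trifluoromethyl on its own does not carry the lower number of compound 2; that number goes with the whole thiazole-bearing group. Set against the nitrile, the picture is less clear, with an at least 1.7-fold lower number from compound 1 to compound 3 (0.24 log units; that floor lies within the scatter), so no order between cyano and trifluoromethyl at this carbon can be drawn. Compound 1 stands only as a limit of the assay, not a true number: the limit of > 200000 nM in this assay, at which 1 of the 3 values shown sits.

As far as these compounds go, it remains open whether the five-membered aromatic ring alone, without its trifluoromethyl, would go with a lower number. From the compounds shown here alone, how a simple methyl, an amine or a carboxylic acid on this carbon would read also remains open.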